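From dichlorophenyl to cyanophenyl on a shared core

The compounds below may be only part of what the source reports. "The series", "measured", "known", "first", "only" and "open" are said of these compounds alone.

Values so far in a functional assay on HepG2 cells (Homo sapiens) for cytotoxicity, read by MTT assay, with a stated time of 24 h; on this read-out higher numbers stand for weaker inhibition and lower numbers for stronger inhibition
- compound 1 `COc1cc(/C=C2\CN(C)C/C(=C\c3ccccc3F)C2=O)cc(OC)c1OC` gives 670 nM
- compound 2 `COc1cc(/C=C2\CN(C)C/C(=C\c3ccc(F)cc3)C2=O)cc(OC)c1OC` gives 7340 nM
- compound 3 `COc1cc(/C=C2\CN(C)C/C(=C\c3ccc(Cl)c(Cl)c3)C2=O)cc(OC)c1OC` gives 6960 nM

Compound 3 belongs to the weaker pair of this small set, and its partner is compound 2: the move a 1.1-fold lower number from compound 2 to compound 3 (0.02 log units; within the scatter) does not separate them. Compound 4 `COc1cc(/C=C2\CN(C)C/C(=C\c3ccc(C#N)cc3)C2=O)cc(OC)c1OC` keeps the shared core and changes one group, as 4-cyanophenyl in place of 3,4-dichlorophenyl on a double-bonded chain carbon bound to a double-bonded ring carbon shows: 4-cyanophenyl in place of 3,4-dichlorophenyl. The measured steps at this same place fall into two kinds. Two start from the 2-fluorophenyl of compound 1 and are large: an 11-fold higher number from compound 1 to compound 2 (1.04 log units; beyond the scatter) and a 10-fold higher number from compound 1 to compound 3 (1.02 log units; beyond the scatter) are both beyond the scatter. Compound 4 lacks that group, and its 4-cyanophenyl reads more like the 4-fluorophenyl of compound 2 at 7340 nM in this assay for now. For the measured compounds named here, no cyano compound has been measured here, so the range stays wide. The expected change is small, a 1.2-fold lower number from compound 3 to compound 4 (0.06 log units; within the scatter) and so no step beyond the scatter. For compound 4 the estimated value is 6000 nM (expected range 2000 nM to 18000 nM).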

Compound 4, half-maximal inhibitory concentration: 1140 nM
Beside the measured number, compound 4's estimate is 5.3-fold (0.72 log units) above it; the measured number lies below the stated range.
By their numbers in this assay, from the lowest: compounds 1 and 4 (each within the scatter of the next); then compounds 3 and 2 (each within the scatter of the next).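

Until now, only the 2-fluorophenyl group stood apart at the stronger end of this assay, but the change to 4-cyanophenyl gives a 6.1-fold lower number from compound 3 to compound 4 (0.79 log units; beyond the scatter), so a second group at this place lowers the number beyond the scatter. Exchanging one atom group on the ring, cyano in place of fluoro on an aromatic carbon, gives a 6.4-fold lower number from compound 2 to compound 4 (0.81 log units; beyond the scatter), so the weak reading of the 4-fluorophenyl group does not extend to every group carried at that ring carbon. The remaining comparison gives a 1.7-fold higher number from compound 1 to compound 4 (0.23 log units; within the scatter), which leaves 4-cyanophenyl and 2-fluorophenyl indistinguishable in this test.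

Nothing available explains why these groups read as they do. On these data alone, whether an amine or a carboxylic acid in place of the cyano would keep the lower number remains open.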